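Swapping 4-methoxyphenyl for 2-fluorophenyl on a shared core

The source may report more compounds than this note shows. Statements on the series, on what has been measured and on what is new or still open speak of the compounds shown alone.

In a functional assay on BGC-823 cells (Homo sapiens) for cytotoxicity, read by MTT assay, with a stated time of 48 h (on this read-out lower numbers stand for stronger inhibition and higher numbers for weaker inhibition), three compounds built on one shared core have been measured so far. Compound 1 (`O=C(CSc1nnc(-c2ccncc2)o1)N/N=C/c1ccc([N+](=O)[O-])cc1`) gives 31500 nM and compound 2 (`O=C(CSc1nnc(-c2ccncc2)o1)N/N=C/c1ccc(O)cc1`) gives 7940 nM on this scale. Compound 3 (`COc1ccc(/C=N/NC(=O)CSc2nnc(-c3ccncc3)o2)cc1`) gives 19800 nM on the same scale. Its standing is set by a 1.6-fold lower number from compound 1 to compound 3 (0.20 log units; within the scatter) and by a 2.5-fold higher number from compound 2 to compound 3 (0.40 log units; beyond the scatter) in this small set, so it sits level with compound 1 within the scatter and clearly on the weaker side of compound 2.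

Among the measured compounds shown here, the next compound, compound 4 (`O=C(CSc1nnc(-c2ccncc2)o1)N/N=C/c1ccccc1F`), has no measurement yet. The change is 2-fluorophenyl in place of 4-methoxyphenyl on a carbon with a double bond to nitrogen. For the measured compounds named here, no measured compound carries fluorine, so the data hold no direct test of this swap. The nearest evidence is the set of swaps on that same aromatic ring, where a 4.0-fold lower number from compound 1 to compound 2 (0.60 log units; beyond the scatter) is the largest step and is still only modest. A step no larger than that modest size is therefore expected, with no firm direction. The expected change is a 1.3-fold lower number from compound 3 to compound 4 (0.12 log units; within the scatter) as an estimate only. In this assay compound 4 is expected at 15000 nM with an estimated range from 6000 nM to 38000 nM overall.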

Compound 4, half-maximal inhibitory concentration: 24000 nM
Compound 4: middle estimate off by 1.6-fold (0.20 log units), on the low side; the measured number falls inside the stated range.
By their numbers in this assay, from the lowest: compound 2; then compounds 3, 4 and 1 (each within the scatter of the next).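

The first fluorine-bearing ring on this carbon with a double bond to nitrogen stays level with two quite different groups in this assay: 2-fluorophenyl in place of 4-methoxyphenyl gives a 1.2-fold higher number from compound 3 to compound 4 (0.08 log units; within the scatter), and in place of 4-nitrophenyl it gives a 1.3-fold lower number from compound 1 to compound 4 (0.12 log units; within the scatter). Against 4-hydroxyphenyl the same group gives a 3.0-fold higher number from compound 2 to compound 4 (0.48 log units; beyond the scatter), so among these four compounds the hydroxy compound alone stands apart, with the lowest number, while the other three cannot be ordered. No measured evidence is at hand to explain why compound 2 separates from the rest or why the other three stay level.

From the compounds shown here alone, whether that separation belongs to the hydroxy group itself remains open, since an amine or a carboxylic acid in its place on the same ring would be needed to tell a special feature of hydroxy from a wider trend. Fluorine appears here only as 2-fluorophenyl, so the compounds shown also leave open whether a ring with two fluorines or a trifluoromethyl group would stay level with compound 4 or move away from it.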